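Swapping sulfur for oxygen on a fused core

The compounds below may be only part of what the source reports. "The series", "measured", "known", "first", "only" and "open" are said of these compounds alone.

Compound 2 `Cc1cccc(Cn2cc(C(=N)S)c3c(N)ncnc32)c1` carries a group of 3 heavy atoms (1 carbon, 1 nitrogen, 1 sulfur; no ring) on an aromatic carbon of its shared core. In a functional assay on KB cells (Homo sapiens) for cytotoxicity (on this read-out higher numbers stand for weaker inhibition and lower numbers for stronger inhibition), compound 2 gives 30000 nM. Compound 1 `Cc1cccc(Cn2cc(C(N)=O)c3c(N)ncnc32)c1` differs from it by a group of 3 heavy atoms (1 carbon, 1 nitrogen, 1 oxygen; no ring) in place of a group of 3 heavy atoms (1 carbon, 1 nitrogen, 1 sulfur; no ring), on an aromatic carbon. In this assay compound 1 reaches only a limit of the assay, > 100000 nM. The step is an at least 3.3-fold higher number from compound 2 to compound 1 (0.52 log units; beyond the scatter), and its size can be read only as a floor because of the limit of > 100000 nM in this assay, at which 1 of the 3 values shown sits.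

Compound 3 `Cc1ccccc1Cn1cc(C(=N)S)c2c(N)ncnc21` is built on a core that differs from that of compound 2 by 2-methylphenyl in place of 3-methylphenyl on a saturated chain carbon bound to an aromatic nitrogen. In this assay compound 3 also reaches only a limit of the assay, > 17000 nM. The step that the limit leaves unreadable from compound 2 to compound 3 cannot be sized because of the limit of > 17000 nM in this assay, at which 1 of the 3 values shown sits.

Compound 4 `Cc1ccccc1Cn1cc(C(N)=O)c2c(N)ncnc21` has not yet been measured. It differs from compound 3 by a group of 3 heavy atoms (1 carbon, 1 nitrogen, 1 oxygen; no ring) in place of a group of 3 heavy atoms (1 carbon, 1 nitrogen, 1 sulfur; no ring), on an aromatic carbon, which is the same change already made from compound 2 to compound 1, at the same place on the shared core. Since that change gave an at least 3.3-fold higher number from compound 2 to compound 1 (0.52 log units; beyond the scatter), the estimated step here is a step that the limit leaves unreadable from compound 3 to compound 4, although the starting point in compound 3 is itself only a limit. Compound 4 is therefore expected to sit at roughly 150000 nM in this assay, most likely again beyond the range the assay can report as a number.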

Compound 4, half-maximal inhibitory concentration: > 100000 nM
Compound 4: no number, only a limit; the forecaster's own chance of this, stated with the estimate: 75%; the middle value does not contradict the limit.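

In this assay compound 4 gives > 100000 nM, which is a limit and not a number. Compound 1 and compound 3 also stand only at limits, so the steps from compound 3 to compound 4 and from compound 1 to compound 4 cannot be read. The compounds shown leave open whether 2-methylphenyl and 3-methylphenyl differ on this read-out, and whether carbamoyl raises the number on the 2-methylphenyl compounds too.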